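Urea series: methyl for isopropyl on the aryl ring

A few compounds are considered here, and "the series" means these few. Any claim that something is new, unique, unknown or untested is made for them only; others in the source may bear on it.

compound 1 `CC(C)c1cccc(C(C)C)c1NC(=O)NC(c1ccccc1)c1ccccc1`: 45 nM
compound 2 `CC(C)c1cccc(C(C)C)c1NC(=O)NCC1(c2ccccc2)CCCCC1`: 21 nM

In an assay on microsomes from intestine for inhibition of acyl-CoA:cholesterol acyltransferase (Oryctolagus cuniculus) (a lower number here means a stronger inhibitor, a higher number a weaker inhibitor), compound 1 gives 45 nM and compound 2 gives 21 nM. Compound 2 holds the lowest number of the two measured; compound 1 lies a step beyond the scatter above it. Compound 3 `Cc1cccc(C(C)C)c1NC(=O)NCC1(c2ccccc2)CCCCC1` is not yet measured. It differs from compound 2 by methyl in place of isopropyl on an aromatic carbon. Among the compounds with values here, no measured pair shows this change, so the expectation rests on the change itself: a moderate rise in the number, beyond the scatter, is expected in this assay. For compound 3 the estimate is 60 nM, range 20 nM to 200 nM. This expected step is a 2.9-fold higher number from compound 2 to compound 3 (0.46 log units; beyond the scatter).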

Compound 3, half-maximal inhibitory concentration: 58 nM
Compound 3: middle estimate off by 1.0-fold (0.01 log units), on the high side; measured number inside the range.
By their numbers in this assay, from the lowest: compound 2; then compounds 1 and 3 (each within the scatter of the next).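

In this assay, within the data shown here, methyl in place of isopropyl on this aromatic carbon gives a 2.8-fold higher number from compound 2 to compound 3 (0.44 log units; beyond the scatter), the first reading of this change. The second isopropyl group stays in place, and with one isopropyl replaced compound 3 still gives 58 nM, so this position tolerates the smaller group with only a modest loss. No measurement bearing on the cause of this step is available. Still open, going by these compounds, is how ethyl, methoxy or chlorine would read at this position, and whether the same change on compound 1 gives a step of similar size.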